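This account rests on a few compounds, and the source may have more. Where it says the series, first, only, none or still open, it means among the compounds named here.

Compound 1 `CC(C)(C)c1cc(NC(=O)[C@@H]2CCCCN2Cc2ccc(Cl)cc2)no1` is the starting point of this step. In an ADME assay (liver) for metabolic stability, with Liver microsome (Homo sapiens) as the target, read by LC-MS, using microsomes and NADPH, tested at 1 uM (a lower number here means that the compound disappears faster, a higher number that the compound lasts longer), compound 1 gives 0.15 h, the lowest of the two plain numbers shown, and it stands beside compound 2 `CC(C)(C)c1cc(NC(=O)[C@@H]2CCCCN2C(=O)c2ccc(Cl)cc2)no1` and compound 3 `CCC(=O)N1CCN(C(=O)N2CCCC[C@H]2C(=O)Nc2cc(C(C)(C)C)on2)CC1`. In this assay compound 2 gives 1.25 h. For compound 3 the result in this assay is reported only as a limit, > 2 h, which is the limit of > 2 h in this assay, at which 1 of the 3 values shown sits. The two measured steps are an 8.3-fold higher number from compound 1 to compound 2 (0.92 log units; beyond the scatter) and an at least 1.6-fold higher number from compound 2 to compound 3 (0.20 log units; that floor lies within the scatter).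

Compound 4 `CC(C)(C)c1cc(NC(=O)[C@@H]2CCCCN2C(=O)N2CCSCC2)no1` has not yet been measured. It differs from compound 1 in one place: (thiomorpholin-4-yl)carbonyl in place of 4-chlorobenzyl on an amine nitrogen in a ring. Both measured steps bear on this change, since the first puts a carbonyl in place of 4-chlorobenzyl on the amine nitrogen in the ring, and the second puts a saturated nitrogen ring on the carbonyl carbon, as in compound 4; a step upward well beyond the scatter is therefore expected in this assay, a 10-fold higher number from compound 1 to compound 4 (1.00 log units; beyond the scatter). Compound 4 is expected to give about 1.5 h in this assay, between 0.5 h and 4 h.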

Compound 4, half-life: < 0.0834 h
Compound 4 ended at the assay's limit; the forecaster's own chance of this, stated with the estimate: 35%; middle value at least 17-fold (1.25 log units) away from the limit.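

What stands on the carbonyl carbon matters more than compounds 2 and 3 could show: in this assay, thiomorpholin-4-yl in place of 4-chlorophenyl gives an at least 14-fold lower number from compound 2 to compound 4 (1.17 log units; beyond the scatter), and thiomorpholin-4-yl in place of 4-propanoylpiperazin-1-yl gives an at least 23-fold lower number from compound 3 to compound 4 (1.37 log units; beyond the scatter). A carbonyl on the amine nitrogen in the ring therefore does not by itself carry the longer half-life, since (thiomorpholin-4-yl)carbonyl in place of 4-chlorobenzyl gives an at least 1.7-fold lower number from compound 1 to compound 4 (0.25 log units; that floor lies within the scatter). The result for compound 4 is a limit and not a number: the limit of < 0.0834 h in this assay, at which 1 of the 4 values shown sits.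

How far compound 4 lies from compound 1 cannot be read from this limit. The compounds shown also leave open whether the sulfur or the ring as a whole matters, a question that morpholin-4-yl on the same carbonyl, with oxygen in place of sulfur, would address.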